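A few compounds are considered here, and "the series" means these few. Any claim that something is new, unique, unknown or untested is made for them only; others in the source may bear on it.

Of the compounds shown here, two that share one core have been tested in a functional assay on cells for agonist activity at C-X-C chemokine receptor type 4 (Homo sapiens), read by fluorescence and calcium flux, with a stated time of 90 s; on this read-out lower numbers stand for an effect already at smaller amounts and higher numbers for an effect only at larger amounts of compound. In this assay compound 1, with the structure `c1ccc2c(c1)CN[C@@H](CN(CCCCNCc1ccncc1)[C@H]1CCCc3cccnc31)C2`, gives only a limit of > 30000 nM. Compound 2, with the structure `c1ccc2c(c1)CN[C@@H](CN(CCCCNC1CCCCC1)[C@H]1CCCc3cccnc31)C2`, likewise gives only a limit of > 30000 nM in this assay. For the measured compounds named here, the single measured step, a step that the two limits leave unreadable from compound 1 to compound 2, therefore cannot be read, and compound 2 stands at the limit, as does the other value shown, (the limit of > 30000 nM in this assay, at which 2 of the 2 values shown sit). Compound 3 has the structure `c1ccc2c(c1)CN[C@@H](CN(CCCCNC1CCSCC1)[C@H]1CCCc3cccnc31)C2`; it differs from compound 2 in that (thian-4-yl in place of cyclohexyl on an amine nitrogen). Going by the values given here, no measured step in this assay bears on this change, and both values shown sit at the limit. Compound 3 is therefore expected to remain at the limit as well, an expected step that the limit leaves unreadable from compound 2 to compound 3 that cannot be read as a real change. The estimated value for compound 3 in this assay is 50000 nM, expected to fall between 15000 nM and 150000 nM.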

Compound 3, half-maximal effective concentration: > 30000 nM
Compound 3: no number, only a limit; the forecaster's own chance of this, stated with the estimate: 90%; the middle value does not contradict the limit.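

Compound 3, like compound 1 and compound 2, gives only a limit in this assay, so no step among these three compounds can be read: the limit of > 30000 nM in this assay, at which 3 of the 3 values shown sit.
The compounds shown leave open whether any of these groups on the amine nitrogen gives a measurable effect in this assay.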